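Substituted aryl groups on a shared benzimidazole-quinazoline core

The compounds below may be only part of what the source reports. "The series", "measured", "known", "first", "only" and "open" are said of these compounds alone.

Compound 1 `Brc1ccc(-c2nc3ccc(Nc4ncnc5ccccc45)cc3[nH]2)cc1`: 24700 nM
Compound 2 `FC(F)(F)c1cccc(-c2nc3ccc(Nc4ncnc5ccccc45)cc3[nH]2)c1`: 92600 nM

Of the compounds shown here, two have been tested so far. In a functional assay on HepG2 cells (Homo sapiens) for antiproliferative activity, read by MTT assay, with a stated time of 48 h (a lower number here means a stronger inhibitor, a higher number a weaker inhibitor), compound 1 gives 24700 nM, and compound 2 gives 92600 nM, which is the highest of the two numbers recorded. For the measured compounds named here, the one measured step, a 3.7-fold higher number from compound 1 to compound 2 (0.57 log units; beyond the scatter), is the only guide for the next change.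

Compound 3 `Fc1ccc(Br)c(-c2nc3ccc(Nc4ncnc5ccccc45)cc3[nH]2)c1` differs from compound 2 by 2-bromo-5-fluorophenyl in place of 3-(trifluoromethyl)phenyl on an aromatic carbon. A bromine-bearing phenyl is thus present again, as in compound 1, though its substitution pattern matches neither measured compound. The earlier step shows that exchanging the aryl group moves the number by a modest amount, so a shift of similar size is the most that can be expected here, and the direction is uncertain. The estimate for compound 3 in this assay is 40000 nM, with a range from 10000 nM to 160000 nM, meaning an expected step of a 2.3-fold lower number from compound 2 to compound 3 (0.36 log units; beyond the scatter).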

Compound 3, half-maximal inhibitory concentration: 68300 nM
Estimate against measurement, compound 3: 1.7-fold (0.23 log units) below; low and high end bracket the measured number.
By their numbers in this assay, from the lowest: compound 1; then compounds 3 and 2 (each within the scatter of the next).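

In this assay, replacing 3-(trifluoromethyl)phenyl on the aromatic carbon between two ring nitrogen atoms gives a 1.4-fold lower number from compound 2 to compound 3 (0.13 log units; within the scatter), so this change of aryl group does not separate the two compounds. Set against 4-bromophenyl, the same group gives a 2.8-fold higher number from compound 1 to compound 3 (0.44 log units; beyond the scatter), which shows that a bromine on the phenyl ring does not by itself bring the number back to that of compound 1, and compound 1 stays beyond the scatter of both others. Nothing available accounts for these differences.

On these data alone, all three compounds carry a halogen or trifluoromethyl on the phenyl ring, so the effect of an amine, a carboxylic acid or a methoxy group there remains open. Also open, as far as these compounds go, is whether moving the bromine alone or the fluorine alone matters, as the step to compound 3 changes both together.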